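A few compounds are considered here, and "the series" means these few. Any claim that something is new, unique, unknown or untested is made for them only; others in the source may bear on it.

Measured compounds in an assay on CHO cells for displacement of a labelled ligand from 5-hydroxytryptamine receptor 1D (Homo sapiens); a higher number here means a weaker inhibitor, a lower number a stronger inhibitor:
- compound 1, `CC(C)=CCCN(C)C1CCN(CCCc2c[nH]c3ccc(-n4cnnc4)cc23)CC1`, gives 2.6 nM
- compound 2, `CC(=O)Nc1ccc(CNC2CCN(CCCc3c[nH]c4ccc(-n5cnnc5)cc34)CC2)cc1`, gives 3 nM
- compound 3, `CN(Cc1ccc(S(C)(=O)=O)cc1)C1CCN(CCCc2c[nH]c3ccc(-n4cnnc4)cc23)CC1`, gives 18 nM

Among these three, compound 3 carries the highest number in this assay, its steps to compound 1 and compound 2 both lying beyond the scatter. Compound 4, `CC(=O)Nc1ccc(CN(C)C2CCN(CCCc3c[nH]c4ccc(-n5cnnc5)cc34)CC2)cc1`, differs from compound 3 by acetamido in place of methylsulfonyl on an aromatic carbon. For the measured compounds named here, one measured step touches this position: a 6.9-fold higher number from compound 1 to compound 3 (0.84 log units; beyond the scatter). Compound 2 bears the same acetamidobenzyl group as compound 4, with a secondary rather than a methylated amine, and its value sits well below that of compound 3. Compound 4 is therefore expected to give a lower number than compound 3, with a 3.0-fold lower number from compound 3 to compound 4 (0.48 log units; beyond the scatter). The estimate for compound 4 in this assay is 6 nM, within 2 nM to 20 nM.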

Compound 4, half-maximal inhibitory concentration: 19 nM
For compound 4 the middle estimate is 3.2-fold (0.50 log units) below the measured one; low and high end bracket the measured number.
By their numbers in this assay, from the lowest: compounds 1 and 2 (each within the scatter of the next); then compounds 3 and 4 (each within the scatter of the next).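

In this assay the methylsulfonyl and acetamido groups on this aromatic carbon cannot be told apart, with a 1.1-fold higher number from compound 3 to compound 4 (0.02 log units; within the scatter). With acetamido in place, methyl on the amine nitrogen in place of hydrogen gives a 6.3-fold higher number from compound 2 to compound 4 (0.80 log units; beyond the scatter), and 4-acetamidophenyl in place of 3-methylbut-2-en-1-yl gives a 7.3-fold higher number from compound 1 to compound 4 (0.86 log units; beyond the scatter). No evidence at hand explains these steps.
The compounds shown leave open whether the methyl on the amine nitrogen gives a similar step with methylsulfonyl in place of acetamido. They also leave open how an amine or a carboxylic acid on this aromatic carbon would compare.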